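Pyridin-3-yl for phenyl in a low-bioavailability series

A few compounds are considered here, and "the series" means these few. Any claim that something is new, unique, unknown or untested is made for them only; others in the source may bear on it.

In an ADME assay on the whole organism (strain Sprague-Dawley) for pharmacokinetics, with Rattus norvegicus as the target, at a dose of 2 mg/kg by the oral route (a higher number here means that a larger share of the oral dose reaches the circulation, a lower number that a smaller share of the oral dose reaches the circulation), compound 1 `Nc1nc2c(s1)CC[C@H]2C(=O)Nc1ccc(C[C@@H]2CC[C@H]([C@H](O)c3cccnc3)N2)cc1` gives 0% and compound 2 `Cc1nc2c(s1)CC[C@H]2C(=O)Nc1ccc(C[C@@H]2CC[C@H]([C@H](O)c3ccccc3)N2)cc1` gives 6%. These two values lie within the scatter of each other, so compound 2 stands level with compound 1 on the numbers available. Compound 3 `Cc1nc2c(s1)CC[C@H]2C(=O)Nc1ccc(C[C@@H]2CC[C@H]([C@H](O)c3cccnc3)N2)cc1` departs from compound 2 in one place: pyridin-3-yl in place of phenyl on a saturated chain carbon bound to an oxygen on a saturated carbon and a saturated ring carbon. Among the measured compounds shown here, no measured pair isolates this change. The estimated change is a number 2 percentage points lower from compound 2 to compound 3 (within the scatter), which means no expected step beyond the scatter in this assay. The slight downward lean rests on compound 1, which also carries pyridin-3-yl and gives 0%, although it differs from compound 3 elsewhere. For compound 3 the expected value is 4%, with an estimated range of 0% to 12%.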

Compound 3, oral bioavailability: 46%
The estimate for compound 3 lay 42 percentage points below the measured number, and the stated range ends below it.
By their numbers in this assay, from the lowest: compounds 1 and 2 (each within the scatter of the next); then compound 3.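

In this assay, pyridin-3-yl in place of phenyl on the saturated chain carbon gives a number 40 percentage points higher from compound 2 to compound 3 (beyond the scatter), so with methyl on the aromatic carbon, the group at this position has a large effect on the read-out. Pyridin-3-yl alone does not secure a high number: with it held constant, methyl in place of amino on an aromatic carbon gives a number 46 percentage points higher from compound 1 to compound 3 (beyond the scatter), and of the compounds shown, only compound 3 carries both methyl and pyridin-3-yl. No measurement shown here accounts for either step.

The compounds shown leave open whether pyridin-2-yl or pyrimidin-5-yl at this place would match pyridin-3-yl. They also leave open whether ethyl in place of methyl on the aromatic carbon would keep the number of compound 3.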